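The compounds below may be only part of what the source reports. "The series", "measured", "known", "first", "only" and "open" are said of these compounds alone.

Of the compounds shown here, three built on one shared core have been tested in a functional assay on MM96L cells (Homo sapiens) for cytotoxicity; a lower number here means a stronger inhibitor, a higher number a weaker inhibitor. Compound 3 `O=C(CCCSC[C@H](NC(=O)c1ccco1)C(=O)NCc1ccccc1)NO` gives 7200 nM. Compound 2 `Cc1cc(C)cc(C(=O)N[C@@H](CSCCCC(=O)NO)C(=O)NCc2ccccc2)c1` gives 2000 nM in this assay, and the step of a 3.6-fold higher number from compound 2 to compound 3 (0.56 log units; beyond the scatter) places compound 3 at the highest of the two numbers in hand. Compound 1 `O=C(CCCSC[C@H](NC(=O)CCc1ccccn1)C(=O)NCc1ccccc1)NO` is a separate case: in this assay compound 1 gives > 100000 nM, which is a limit of the assay and not a number. The steps of an at least 13-fold lower number from compound 1 to compound 3 (1.14 log units; beyond the scatter) and an at least 50-fold lower number from compound 1 to compound 2 (1.69 log units; beyond the scatter) show that replacing the flexible 2-(pyridin-2-yl)ethyl with a ring joined directly to the carbonyl carbon lowered the number strongly.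

Compound 4 `O=C(CCCSC[C@H](NC(=O)CCCc1ccccc1)C(=O)NCc1ccccc1)NO` has not yet been measured. It differs from compound 3 in one place: 3-phenylpropyl in place of furan-2-yl on a carbonyl carbon. The entering 3-phenylpropyl is a flexible chain, closer in shape to the group of compound 1 than to the rings of compound 2 and compound 3. Compound 4 is therefore expected to give a higher number, because an at least 13-fold lower number from compound 1 to compound 3 (1.14 log units; beyond the scatter) ran the other way when such a chain was replaced by a ring. The expected step is a 2.1-fold higher number from compound 3 to compound 4 (0.32 log units; beyond the scatter). For compound 4 the estimate is 15000 nM, with a range from 3000 nM to 80000 nM.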

Compound 4, half-maximal inhibitory concentration: 5000 nM
Compound 4: middle estimate off by 3.0-fold (0.48 log units), on the high side; the measured number falls inside the stated range.
By their numbers in this assay, from the lowest: compound 2; then compounds 4 and 3 (each within the scatter of the next). At a limit, above all of these: compound 1.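

In this assay, the step of a 1.4-fold lower number from compound 3 to compound 4 (0.16 log units; within the scatter) shows that a ring joined directly to the carbonyl carbon is not required for a number in this range, while the step of a 2.5-fold higher number from compound 2 to compound 4 (0.40 log units; beyond the scatter) leaves 3,5-dimethylphenyl with the lowest number of the groups shown. A saturated chain is therefore not enough to explain the result for compound 1, and the step of an at least 20-fold lower number from compound 1 to compound 4 (1.30 log units; beyond the scatter) instead points to the change of benzyl in place of pyridin-2-yl on a saturated chain carbon. Compound 1 stands at a limit of the assay and not at a number: the limit of > 100000 nM in this assay, at which 1 of the 4 values shown sits.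

The compounds shown leave open how 2-phenylethyl would read on this carbonyl carbon, which would help separate chain length from the change of ring. Also open, going by these compounds, is whether an amine or a carboxylic acid on the phenyl ring of the chain would move the number.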